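A 4-methoxyphenyl replacement awaits its measurement

A few compounds are considered here, and "the series" means these few. Any claim that something is new, unique, unknown or untested is made for them only; others in the source may bear on it.

In a functional assay on MOLT-4 cells (Homo sapiens) for antiproliferative activity, read by CCK-8 assay, with a stated time of 72 h (a higher number here means a weaker inhibitor, a lower number a stronger inhibitor), compound 1 (`Cc1cc(Nc2cc(N3CCN(C)CC3)nc(Nc3ccc(S(N)(=O)=O)cc3)n2)n[nH]1`) gives 648 nM while compound 2 (`Cc1cc(Nc2cc(N3CCN(C)CC3)nc(Nc3cccc(Cl)c3)n2)n[nH]1`) gives 20.1 nM and so holds the lower of the two numbers. Among the measured compounds shown here, the single measured step shows a 32-fold lower number from compound 1 to compound 2 (1.51 log units; beyond the scatter) with 3-chlorophenyl in place of 4-sulfamoylphenyl on a nitrogen on an aromatic ring, and it is large and beyond the scatter. Compound 3 (`COc1ccc(Nc2nc(Nc3cc(C)[nH]n3)cc(N3CCN(C)CC3)n2)cc1`) is still unmeasured and has 4-methoxyphenyl in place of 3-chlorophenyl on a nitrogen on an aromatic ring. That one step involved a different incoming group, so it shows only that this place can move the number widely. Compound 1 at 648 nM marks how far one replacement of 3-chlorophenyl has gone. A moderate rise in the number (a 3.5-fold higher number from compound 2 to compound 3 (0.54 log units; beyond the scatter)) is expected, smaller than the measured step. Compound 3 is estimated at 70 nM with an expected range from 22 nM to 220 nM in this assay once tested.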

Compound 3, half-maximal inhibitory concentration: 116 nM
Beside the measured number, compound 3's estimate is 1.7-fold (0.22 log units) below it; measured number inside the range.
By their numbers in this assay, from the lowest: compound 2; then compound 3; then compound 1.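

In this assay, the place on a nitrogen on an aromatic ring now gives three separated readings rather than two, with a 5.8-fold higher number from compound 2 to compound 3 (0.76 log units; beyond the scatter) and a 5.6-fold lower number from compound 1 to compound 3 (0.75 log units; beyond the scatter). The third group therefore lands between the earlier two, so among these compounds the position gives graded results, not simply a high or a low number, and exchanging sulfamoyl for methoxy on the aromatic carbon recovers only part of the gap to the 3-chlorophenyl group. Nothing available here explains this order.

Compound 2 and compound 3 differ in both the substituent and where it sits on the ring, so the compounds shown cannot separate those two contributions. Also open, from the compounds shown here alone, is how a plain phenyl, or a phenyl bearing an amine or a carboxylic acid, would read in this assay.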